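A few compounds are considered here, and "the series" means these few. Any claim that something is new, unique, unknown or untested is made for them only; others in the source may bear on it.

In a functional assay on CCRF-CEM cells (Homo sapiens) for cytotoxicity, in the absence of a further agent (on this read-out lower numbers stand for stronger inhibition and higher numbers for weaker inhibition), compound 3 `COC(=O)c1ccc(CN(CCCc2c(N)nc(N)nc2O)c2cc(F)c(F)cc2[N+](=O)[O-])cc1` gives 59000 nM, the lowest of the two numbers shown. Compound 2 `Nc1nc(N)c(CCCNc2cc(F)c(F)cc2[N+](=O)[O-])c(O)n1` gives 97000 nM in this assay. Compound 1 `Nc1nc(N)c(CCCN(Cc2ccc(NC(CCC(=O)O)C(=O)O)cc2)c2cc(F)c(F)cc2[N+](=O)[O-])c(O)n1` reaches only a limit in this assay, > 100000 nM, as recorded by the limit of > 100000 nM in this assay, at which 1 of the 3 values shown sits. The two measured steps, a 1.6-fold lower number from compound 2 to compound 3 (0.22 log units; within the scatter) and an at least 1.6-fold lower number from compound 1 to compound 3 (0.22 log units; that floor lies within the scatter), both concern the group on the benzyl side and neither alters the nitrophenyl ring.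

Compound 4 `COC(=O)c1ccc(CN(CCCc2c(N)nc(N)nc2O)c2ccc([N+](=O)[O-])c(F)c2F)cc1` differs from compound 3 in that (2,3-difluoro-4-nitrophenyl in place of 4,5-difluoro-2-nitrophenyl on an amine nitrogen). Going by the values given here, no measured step bears on this rearrangement, so no shift beyond the scatter is expected. Compound 4 is therefore estimated to give about 59000 nM in this assay, with a range from 25000 nM to 140000 nM. The expected step is no change at the digits printed from compound 3 to compound 4 (within the scatter).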

Compound 4, half-maximal inhibitory concentration: 41000 nM
The estimate for compound 4 lay 1.4-fold (0.16 log units) above the measured number; measured number inside the range.
By their numbers in this assay, from the lowest: compounds 4, 3 and 2 (each within the scatter of the next, the first and the last beyond it). At a limit, above all of these: compound 1.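

Compound 4 is the first compound shown with a change on the aromatic ring on the amine nitrogen, and in this assay the step is a 1.4-fold lower number from compound 3 to compound 4 (0.16 log units; within the scatter). Exchanging 4,5-difluoro-2-nitrophenyl for 2,3-difluoro-4-nitrophenyl, with the same atoms joined differently, therefore gives no difference that can be told from the scatter. Nothing shown gives a reason for this result.

Still open, from the compounds shown here alone, is what an amine in place of the nitro group on this ring would do. So is whether a carboxylic acid in place of the methoxycarbonyl would change the cytotoxicity of compound 4.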